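The source may report more compounds than this note shows. Statements on the series, on what has been measured and on what is new or still open speak of the compounds shown alone.

Compound 1 `CN(C)CCn1c(=O)c(=Cc2ccc(F)c(F)c2)s/c1=C1\C(=O)Nc2cc(F)ccc21` is the weaker of the two measured compounds in a functional assay on NCI-H460 cells (Homo sapiens) for inhibition, read by MTT assay, with a stated time of 72 h; a lower number here means a stronger inhibitor, a higher number a weaker inhibitor: compound 1 gives 6400 nM, while compound 2 `CCN(CC)CCCn1c(=O)c(=Cc2ccc(F)c(F)c2)s/c1=C1\C(=O)Nc2cc(F)ccc21` gives 1120 nM. Among the compounds with values here, the single measured step, a 5.7-fold lower number from compound 1 to compound 2 (0.76 log units; beyond the scatter), concerns the amine on the side chain and not the part of the molecule that changes here. Compound 3 `COc1ccc(C=c2s/c(=C3\C(=O)Nc4cc(F)ccc43)n(CCN(C)C)c2=O)cc1` differs from compound 1 at another place: 4-methoxyphenyl in place of 3,4-difluorophenyl on a double-bonded chain carbon bound to an aromatic carbon. Within the data shown here, no measured step touches this aromatic group, so nothing in the data bears directly on the change, and the expectation rests on compound 1 alone, with a wide range because the direction is unknown. Compound 3 is therefore expected to give about 8000 nM, estimated to fall between 2500 nM and 25000 nM. Expressed as a step, this estimate amounts to an expected 1.3-fold higher number from compound 1 to compound 3 (0.10 log units; within the scatter), which would stay within the usual scatter.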

Compound 3, half-maximal inhibitory concentration: 2200 nM
Compound 3: middle estimate off by 3.6-fold (0.56 log units), on the high side; measured number below the stated range.
By their numbers in this assay, from the lowest: compounds 2 and 3 (each within the scatter of the next); then compound 1.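

In this assay, the aromatic group on the double-bonded chain carbon proves to matter: 4-methoxyphenyl in place of 3,4-difluorophenyl gives a 2.9-fold lower number from compound 1 to compound 3 (0.46 log units; beyond the scatter), so the number responds to this position and not only to the amine on the side chain. Both groups hold one six-membered aromatic ring of carbon only and the same count of heavy atoms, yet the swap removes two fluorine atoms and adds a methoxy group in a single step, so it cannot show which of these alterations carries the change. Nothing available here explains why the number falls. 

Still open, on these data alone, is whether 4-fluorophenyl or 3,4-dimethoxyphenyl would separate the loss of fluorine from the gain of methoxy. Also open, as far as these compounds go, is whether 4-methoxyphenyl gives a similar step on the side chain of compound 2.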